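The compounds below may be only part of what the source reports. "The series", "measured", "known", "first", "only" and "open" are said of these compounds alone.

Measured compounds:
- compound 1 `Brc1cn2ccnc2c(-c2ccc3ncn(C4CCCCC4)c3c2)n1`: in a functional assay on ACHN cells (Homo sapiens) for inhibition, read by sulforhodamine B assay, with a stated time of 48 h, tested at 10 uM (a higher number here means more inhibition at the concentration tested (going by the name of the read-out), a lower number less inhibition), compound 1 gives 11.5%
- compound 2 `Fc1ccc(-c2cn3ccnc3c(-c3ccc4ncn(C5CCCCC5)c4c3)n2)cc1`: compound 2 gives 9.02%
- compound 3 `c1cn2cc(-c3ccsc3)nc(-c3ccc4ncn(C5CCCCC5)c4c3)c2n1`: compound 3 gives 5.76%

All three share the same core and differ only in the group on one aromatic carbon. On the numbers shown, compound 3 is the lowest of the three, yet its distances to the others are small: a number 3.3 percentage points lower from compound 2 to compound 3 (within the scatter) and a number 5.7 percentage points lower from compound 1 to compound 3 (within the scatter). The step from compound 3 to compound 4 `Fc1ccccc1-c1cn2ccnc2c(-c2ccc3ncn(C4CCCCC4)c3c2)n1` is this: 2-fluorophenyl in place of thiophen-3-yl on an aromatic carbon. The measured steps that bear on it all swap one group at the same place, and none left the scatter: a number 2.5 percentage points lower from compound 1 to compound 2 (within the scatter), a number 5.7 percentage points lower from compound 1 to compound 3 (within the scatter), a number 3.3 percentage points lower from compound 2 to compound 3 (within the scatter). Whether the group there is bromo, 4-fluorophenyl or thiophen-3-yl, the inhibition stays low and nearly flat. A 2-fluorophenyl at that place is therefore expected to behave alike, giving an estimated step of a number 2.2 percentage points higher from compound 3 to compound 4 (within the scatter), none beyond the scatter. Compound 4 is expected to give 8%, with an estimated range from 0% to 18%.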

Compound 4, a percentage reported as inhibition, at one concentration (the size of the read-out at that concentration, not a potency): 13.2%
For compound 4 the middle estimate is 5.2 percentage points below the measured one; measured number inside the range.
By their numbers in this assay, from the lowest: compounds 3, 2, 1 and 4 (each within the scatter of the next).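

In this assay, a fourth group at this position, the 2-fluorophenyl, falls in line with the other three, whichever group it replaces: thiophen-3-yl (a number 7.4 percentage points higher from compound 3 to compound 4 (within the scatter)), 4-fluorophenyl (a number 4.2 percentage points higher from compound 2 to compound 4 (within the scatter)) or bromo (a number 1.7 percentage points higher from compound 1 to compound 4 (within the scatter)). The step from 4-fluorophenyl is the new comparison, and it shows that placing the fluorine differently on the same ring gives no difference that stands out from the scatter. So far, no group at this position sets one compound apart from the others.

From the compounds shown here alone, all four groups are either bromo or an aromatic ring, so what an amine, a carboxylic acid or a longer alkyl chain would do here remains open. Nothing at hand offers a reason for these numbers.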